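Replacing the amide side chain of compound 3

This account rests on a few compounds, and the source may have more. Where it says the series, first, only, none or still open, it means among the compounds named here.

In a functional assay on HT-29 cells (Homo sapiens) for inhibition, read by CellTiter-Glo, with a stated time of 72 h (on this read-out lower numbers stand for higher toxicity in this test and higher numbers for lower toxicity in this test), compound 3 (`CC1=C(CC(=O)NCCN2CCCC2)c2cc(F)ccc2/C1=C\c1nc2ccccc2s1`) gives 1210 nM. Compound 1 (`CC1=C(CC(=O)N(C)CCN(C)C)c2cc(F)ccc2/C1=C\c1nc2ccccc2s1`) gives 2020 nM, within the scatter of compound 3. Compound 2 (`CC1=C(CC(=O)N2CCN(c3ccncc3)CC2)c2cc(F)ccc2/C1=C\c1ccc([S+](C)[O-])cc1`) gives 9200 nM, a higher number that lies beyond the scatter from compound 3.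

Compound 4 (`CC1=C(CC(=O)N2CCN(c3ccncc3)CC2)c2cc(F)ccc2/C1=C\c1nc2ccccc2s1`) keeps the rest of compound 3 and changes one group: 4-(pyridin-4-yl)piperazin-1-yl in place of (2-(pyrrolidin-1-yl)ethyl)amino on a carbonyl carbon. In words, 4-(pyridin-4-yl)piperazin-1-yl stands in place of (2-(pyrrolidin-1-yl)ethyl)amino on a carbonyl carbon.

For the measured compounds named here, only one measured step falls at this place, a 1.7-fold lower number from compound 1 to compound 3 (0.22 log units; within the scatter), and it stays within the scatter. That step exchanges one open chain for another, so it is only a loose guide to the larger change here. Compound 2 carries the same 4-(pyridin-4-yl)piperazin-1-yl group, but it also differs from compound 4 at the other end of the shared core. Compound 2 with 9200 nM therefore argues for only a modest upward lean, since the two changes cannot be separated on these data.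

The expected change is a 1.8-fold higher number from compound 3 to compound 4 (0.26 log units; within the scatter), a rise not clearly beyond the scatter. For compound 4 the estimated value in this assay is 2200 nM, with an expected range from 800 nM to 6500 nM.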

Compound 4, half-maximal cytotoxic concentration: 5250 nM
Estimate against measurement, compound 4: 2.4-fold (0.38 log units) below, and the stated range covers the measured number.
By their numbers in this assay, from the lowest: compounds 3 and 1 (each within the scatter of the next); then compounds 4 and 2 (each within the scatter of the next).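

In this assay, for the compounds shown here, the change on this carbonyl carbon now gives a step beyond the scatter (a 4.3-fold higher number from compound 3 to compound 4 (0.64 log units; beyond the scatter)), and the same entering group does so against the other chain (a 2.6-fold higher number from compound 1 to compound 4 (0.41 log units; beyond the scatter)), whereas the one earlier step at this place stayed within it (a 1.7-fold lower number from compound 1 to compound 3 (0.22 log units; within the scatter)). With 4-(pyridin-4-yl)piperazin-1-yl held fixed, the exchange of groups on the double-bonded chain carbon stays within the scatter (a 1.8-fold lower number from compound 2 to compound 4 (0.24 log units; within the scatter)), so among these compounds the clear steps are seen at the carbonyl carbon and not at that second place. The data shown offer no measurement that explains these steps.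

The compounds shown do not separate the contribution of the piperazine ring from that of the attached pyridin-4-yl ring, or from that of losing the amide hydrogen. Going by these compounds, a plain piperidin-1-yl group, a 4-methylpiperazin-1-yl group or a 4-phenylpiperazin-1-yl group on the same carbonyl carbon would divide the step from compound 3 into those parts, and whether the step holds with other groups on the double-bonded chain carbon also remains open.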